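This account rests on a few compounds, and the source may have more. Where it says the series, first, only, none or still open, it means among the compounds named here.

Measured compounds in an in vitro assay on CHO cells for displacement of a labelled ligand from Bombesin receptor subtype-3 (Homo sapiens), read by scintillation counting, with a stated time of 2 h; a lower number here means a stronger inhibitor, a higher number a weaker inhibitor:
Compound 1, `CCC(C)(C)Cc1c[nH]c(CCc2ccc(-c3cccnc3)cc2)n1`, gives 7.5 nM.
Compound 2, `CCC(C)(C)Cc1c[nH]c(CCc2ccc(-n3ncnn3)cc2)n1`, gives 205 nM.
Compound 3, `CCC(C)(C)Cc1c[nH]c(CCc2ccc(-c3cccnc3C(=O)O)cc2)n1`, gives 560 nM.

Compound 2 holds the second highest of the three numbers in this assay. Its nearest neighbour is compound 3, with a 2.7-fold higher number from compound 2 to compound 3 (0.44 log units; beyond the scatter), and its furthest is compound 1, with a 27-fold higher number from compound 1 to compound 2 (1.44 log units; beyond the scatter).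

Compound 4, `CCC(C)(C)Cc1c[nH]c(CCc2ccc(-n3cncn3)cc2)n1`, has not yet been measured. It differs from compound 2 in one place: 1H-1,2,4-triazol-1-yl in place of 2H-tetrazol-2-yl on an aromatic carbon. For the measured compounds named here, two measured steps touch this position. The large step of a 27-fold higher number from compound 1 to compound 2 (1.44 log units; beyond the scatter) shows that exchanging pyridin-3-yl for 2H-tetrazol-2-yl at this carbon costs a great deal, and the modest step of a 2.7-fold higher number from compound 2 to compound 3 (0.44 log units; beyond the scatter) shows that 2-carboxypyridin-3-yl at the same carbon gives a still higher number. Going by the values given here, neither step swaps one five-membered ring for another, so there is no direct precedent. Since the ring that leaves and the ring that enters are of the same size and differ only in one ring atom, the expectation is a step within or close to the scatter, with no strong direction. Compound 4 is therefore estimated at 180 nM, within 70 nM to 500 nM. The expected step is a 1.1-fold lower number from compound 2 to compound 4 (0.06 log units; within the scatter).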

Compound 4, half-maximal inhibitory concentration: 340 nM
Estimate against measurement, compound 4: 1.9-fold (0.28 log units) below; low and high end bracket the measured number.
By their numbers in this assay, from the lowest: compound 1; then compounds 2, 4 and 3 (each within the scatter of the next, the first and the last beyond it).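

In this assay, the step of a 1.7-fold higher number from compound 2 to compound 4 (0.22 log units; within the scatter) lies within the scatter, so at this aromatic carbon the data do not separate 1H-1,2,4-triazol-1-yl from 2H-tetrazol-2-yl, two five-membered aromatic rings with 3 and 4 hetero atoms. The step of a 1.6-fold lower number from compound 3 to compound 4 (0.22 log units; within the scatter) is also within the scatter, while the large step of a 45-fold higher number from compound 1 to compound 4 (1.66 log units; beyond the scatter) shows that the gap from pyridin-3-yl is not peculiar to the tetrazole but appears with a second five-membered ring. Nothing available accounts for the gap between these groups.

The compounds shown leave open whether another six-membered ring, such as phenyl or pyrimidin-5-yl, would match the low number of compound 1. They also leave open whether a five-membered ring with fewer ring nitrogens, such as pyrazol-1-yl or imidazol-1-yl, would narrow that gap.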